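Swapping Methoxy for (Trifluoromethyl)sulfanyl in the Anilide Series

The compounds below may be only part of what the source reports. "The series", "measured", "known", "first", "only" and "open" are said of these compounds alone.

- compound 1 `C=C(Br)C(=O)Nc1cccc(/C=C/C(=O)Nc2ccc(C)cc2)c1` gives 1500 nM
- compound 2 `C=C(Br)C(=O)Nc1cccc(/C=C/C(=O)Nc2ccc(OC)cc2)c1` gives 550 nM

In a functional assay on LoVo cells (Homo sapiens) for inhibition, read by MTT assay, with a stated time of 72 h (a higher number here means a weaker inhibitor, a lower number a stronger inhibitor), compound 2 holds the lower of the two numbers, 550 nM. Compound 3 `C=C(Br)C(=O)Nc1cccc(/C=C/C(=O)Nc2ccc(SC(F)(F)F)cc2)c1` differs from compound 2 in one place, with (trifluoromethyl)sulfanyl in place of methoxy on an aromatic carbon, para to a large group ((trifluoromethyl)sulfanyl in place of methoxy on an aromatic carbon). Among the compounds with values here, one measured step bears on that carbon, the modest 2.7-fold lower number from compound 1 to compound 2 (0.44 log units; beyond the scatter). That step does not involve the entering group, so no direction can be argued and no step beyond the scatter is firmly expected. The estimated step is a 1.2-fold higher number from compound 2 to compound 3 (0.07 log units; within the scatter). For compound 3 the estimated value is 650 nM, with an expected range from 180 nM to 2300 nM.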

Compound 3, half-maximal inhibitory concentration: 29300 nM
Compound 3: middle estimate off by 45-fold (1.65 log units), on the low side, and the stated range ends below it.
By their numbers in this assay, from the lowest: compound 2; then compound 1; then compound 3.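

Putting (trifluoromethyl)sulfanyl on this aromatic carbon gives a 53-fold higher number from compound 2 to compound 3 (1.73 log units; beyond the scatter) in this assay, and a 20-fold higher number from compound 1 to compound 3 (1.29 log units; beyond the scatter). The earlier exchange of methyl for methoxy had moved the number only modestly, so this position is now shown to allow much larger losses than that step revealed. Nothing available here accounts for the loss. The three compounds leave open whether it tracks the sulfur or the fluorine atoms of the entering group. Going by these compounds, how a methylsulfanyl group or an amine on this carbon would read also remains open.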